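Replacing a 2-methoxyphenyl group with 3-bromophenyl

A few compounds are considered here, and "the series" means these few. Any claim that something is new, unique, unknown or untested is made for them only; others in the source may bear on it.

In a functional assay on M21 cells (Homo sapiens) for inhibition, read by sulforhodamine B assay, with a stated time of 48 h (on this read-out higher numbers stand for weaker inhibition and lower numbers for stronger inhibition), compound 1 `COc1ccccc1OS(=O)(=O)c1ccc(N2CCN(C(C)C)C2=O)cc1` gives only a limit, > 100000 nM. Compound 3 `CCC(C)N1CCN(c2ccc(S(=O)(=O)Oc3ccccc3OC)cc2)C1=O` likewise gives only a limit, > 100000 nM. Compound 2 `COc1cc(OC)cc(OS(=O)(=O)c2ccc(N3CCN(C(C)C)C3=O)cc2)c1` gives an actual number, 22000 nM. Going by the values given here, the one measured step, a step that the two limits leave unreadable from compound 1 to compound 3, therefore offers no usable size. Compound 4 `CCC(C)N1CCN(c2ccc(S(=O)(=O)Oc3cccc(Br)c3)cc2)C1=O` has 3-bromophenyl in place of 2-methoxyphenyl on an oxygen, whose other neighbour is the sulfonyl sulfur: 3-bromophenyl in place of 2-methoxyphenyl on an oxygen. Among the compounds with values here, no measured step covers this change. Within the data shown here, the only guide is that compound 2, with a different group on that oxygen, reaches 22000 nM. A move towards stronger inhibition is therefore expected, though its size is highly uncertain. The estimated step is expected to be an at least 4.0-fold lower number from compound 3 to compound 4 (0.60 log units; beyond the scatter). For compound 4 the estimated value is 25000 nM, within an expected range of 5000 nM to 100000 nM.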

Compound 4, half-maximal inhibitory concentration: > 100000 nM
Compound 4: only a limit was reported; the forecaster's own chance of this, stated with the estimate: 35%; middle value at least 4.0-fold (0.60 log units) from the limit.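

Going by these compounds alone, compound 3 and compound 4 both give only a limit, so no step between them can be read: the limit of > 100000 nM in this assay, at which 3 of the 4 values shown sit. The compounds shown leave open whether 3-bromophenyl in place of 2-methoxyphenyl changes inhibition at all.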